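Replacing hydroxy with nitro in compound 1

The source may hold more compounds than are shown below. What is called first, only, known or untested is meant among the compounds shown, and "the series" means these compounds.

Measured in a functional assay on HeLa cells (Homo sapiens) for antiproliferative activity, read by sulforhodamine B assay, with a stated time of 48 h; on this read-out higher numbers stand for weaker inhibition and lower numbers for stronger inhibition:
Compound 1 `COc1ccc(C(=O)/C=C\Nc2ccc(-c3nc4cc(OC)c(OC)c(OC)c4s3)cc2C)cc1O` gives 11400 nM
Compound 2 `COc1cc(C(=O)/C=C\Nc2ccc(-c3nc4cc(OC)c(OC)c(OC)c4s3)cc2)c(Br)c(OC)c1OC` gives 6600 nM

Only these two values are available so far. In this assay compound 1 gives 11400 nM and thus lies within the scatter of compound 2, so the two cannot be ranked.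

Compound 3 (`COc1ccc(C(=O)/C=C\Nc2ccc(-c3nc4cc(OC)c(OC)c(OC)c4s3)cc2C)cc1[N+](=O)[O-]`) has not yet been measured. It departs from compound 1 in one place, where 3-hydroxy-4-methoxyphenyl becomes 4-methoxy-3-nitrophenyl. This puts nitro in place of hydroxy on an aromatic carbon, ortho to a methoxy group and meta to a large group.

Among the measured compounds shown here, no two measured compounds differ in a single place, so nothing measured speaks directly to this exchange. No step beyond the scatter is therefore expected in this assay in either direction, although the uncertainty is wide. The expected change is a 1.1-fold lower number from compound 1 to compound 3 (0.06 log units; within the scatter) and remains only an estimate. For compound 3 the estimated value is 10000 nM with an expected range from 3000 nM to 35000 nM in this measurement.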

Compound 3, half-maximal inhibitory concentration: 13400 nM
Compound 3: the middle estimate sits 1.3-fold (0.13 log units) below what was measured, and the stated range covers the measured number.
By their numbers in this assay, from the lowest: compounds 2, 1 and 3 (each within the scatter of the next, the first and the last beyond it).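

In this assay, among the compounds shown here, the exchange of hydroxy for nitro on an aromatic carbon, ortho to a methoxy group and meta to a large group, gives the first comparison in which two measured compounds differ in one place: a 1.2-fold higher number from compound 1 to compound 3 (0.07 log units; within the scatter). At this position, then, 3-hydroxy-4-methoxyphenyl and 4-methoxy-3-nitrophenyl cannot be told apart in this read-out, even though the exchange removes the hydrogen-bond donor and replaces one heavy atom with three. No independent measurement is available to explain this outcome.

For the compounds shown here, this single pair leaves open whether an amine or a carboxylic acid in the same place would give a step beyond the scatter, since hydroxy and nitro are the only two groups compared there. It also leaves open whether the exchange would read the same if the neighbouring methoxy group were replaced by an ethoxy group or a longer chain.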